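Methylsulfonyl in Place of an Oxadiazole in a Cytotoxicity Screen

The source may hold more compounds than are shown below. What is called first, only, known or untested is meant among the compounds shown, and "the series" means these compounds.

Compound 2 `Cc1nc(-c2cccc(C(=O)N3CCCC(C(=O)Nc4ccc(Cl)cc4)C3)c2)no1` was examined in an ADME assay on PC-3 cells (Homo sapiens) for cytotoxicity, read by WST assay, tested at 100 uM (a higher number here means more inhibition at the concentration tested (going by the name of the read-out), a lower number less inhibition), where compound 2 gives 0%. It stands level with its companions: in this assay compound 1 `O=C(Nc1cccc(N2CCCC2=O)c1)C1CCCN(C(=O)c2cc(C(F)(F)F)cc(C(F)(F)F)c2)C1` gives 0%, and compound 3 `O=C(Nc1cccc(Cc2ccccc2)c1)C1CCCN(C(=O)c2cccc(-c3ccco3)c2)C1` gives 0%. All three values lie within the scatter of one another, so none can be set apart. Compound 4 `CS(=O)(=O)c1cccc(C(=O)N2CCCC(C(=O)Nc3ccc(Cl)cc3)C2)c1` has not yet been measured. It differs from compound 2 in one place: methylsulfonyl in place of 5-methyl-1,2,4-oxadiazol-3-yl on an aromatic carbon. Among the measured compounds shown here, no step between measured compounds differing at a single position is available, so the outcome can only be expected. Because compound 1 gives 0% and compound 3 gives 0% despite their different builds, the step of no change at the digits printed from compound 2 to compound 4 (within the scatter) is expected to be none beyond the scatter. Compound 4 is estimated at 0%, within a range from -8% to 10%.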

Compound 4, a percentage reported as inhibition, at one concentration (the size of the read-out at that concentration, not a potency): 2%
Beside the measured number, compound 4's estimate is 2 percentage points below it; measured number inside the range.
By their numbers in this assay, from the lowest: compounds 1, 2, 3 and 4 (each within the scatter of the next).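

In this assay, among the compounds shown here, the exchange gives the first single-place step at this position, a number 2 percentage points higher from compound 2 to compound 4 (within the scatter) and so methylsulfonyl and 5-methyl-1,2,4-oxadiazol-3-yl cannot be told apart on this aromatic carbon. The five-membered aromatic ring can thus be replaced by a group with no ring without the read-out leaving the scatter. Nothing at hand gives a measured property that would explain this outcome. As far as these compounds go, whether an amine or a carboxylic acid on the same aromatic carbon would move the read-out beyond the scatter stays open, as does whether any group at this position would do so.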